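The source may hold more compounds than are shown below. What is called first, only, known or untested is meant among the compounds shown, and "the series" means these compounds.

Working notes on the series.

Three members of the series have been measured in a physicochemical assay for lipophilicity, measured as octanol-water partition; a lower number here means a more polar compound, a higher number a more lipophilic compound. Compound 1 `O=C(NNc1ccnc2cc(Cl)ccc12)c1ccccc1/N=C/c1ccccc1Cl` gives 5.5. Compound 2 `O=C(NNc1ccnc2cc(Cl)ccc12)c1ccccc1/N=C/c1ccc(Cl)cc1Cl` gives 6.22. Compound 3 `COc1ccc(/C=N/c2ccccc2C(=O)NNc2ccnc3cc(Cl)ccc23)cc1` gives 5, the lowest of the three numbers; its nearest neighbour is compound 1 and its furthest compound 2. The measured steps are a number 0.72 log units higher from compound 1 to compound 2 (beyond the scatter), a number 0.50 log units lower from compound 1 to compound 3 (beyond the scatter) and a number 1.22 log units lower from compound 2 to compound 3 (beyond the scatter).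

Compound 4 `O=C(NNc1ccnc2cc(Cl)ccc12)c1ccccc1/N=C/c1cc2ccccc2[nH]c1=O` is not yet measured. It differs from compound 3 in one place: a group of 11 heavy atoms (9 carbon, 1 nitrogen, 1 oxygen; one six-membered aromatic ring of carbon only, one six-membered aromatic ring with 1 hetero atom) in place of a group of 8 heavy atoms (7 carbon, 1 oxygen; one six-membered aromatic ring of carbon only), on a carbon with a double bond to nitrogen. Going by the values given here, the entering group carries 1 hydrogen-bond donor and is the larger of the two groups, and it brings one six-membered aromatic ring with 1 hetero atom that none of the measured compounds holds. Among the compounds with values here, no measured step bears directly on this change; the steps from compound 1 to compound 2 and from compound 1 to compound 3 exchange chloro and methoxy substituents only, and were modest, while the step from compound 2 to compound 3 was large. The expectation for compound 4 is therefore a downward step in this assay of a number 0.50 log units lower from compound 3 to compound 4 (beyond the scatter), beyond the scatter, with wide uncertainty. Compound 4 is estimated at 4.5, within a range from 3.8 to 5.2.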

Compound 4, partition coefficient: 4.65
Estimate against measurement, compound 4: 0.15 log units below; the measured number falls inside the stated range.
By their numbers in this assay, from the lowest: compound 4; then compound 3; then compound 1; then compound 2.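

In this assay, the group entering on the carbon with a double bond to nitrogen gives the lowest number of the series, with a number 0.35 log units lower from compound 3 to compound 4 (beyond the scatter), and it extends the range at this position with a number 0.85 log units lower from compound 1 to compound 4 (beyond the scatter) and a number 1.57 log units lower from compound 2 to compound 4 (beyond the scatter). The number here does not rise with the heavy-atom count of the group: the largest group, with its six-membered aromatic ring with 1 hetero atom and its hydrogen-bond donor, stands lowest, while the two groups of 8 heavy atoms in compound 2 and compound 3 stand far apart. Nothing on hand accounts for these differences.

The entering group brings its second ring, its hetero atom and its hydrogen-bond donor together, so the compounds shown do not separate what each contributes to the step. Where a simple amine, a 4-aminophenyl group or a pyridyl group on the same carbon would fall in this assay remains open, as does whether such a group would stand closer to compound 3 or to compound 4.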